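Second Chloro on the Core of Compound 1

The source may hold more compounds than are shown below. What is called first, only, known or untested is meant among the compounds shown, and "the series" means these compounds.

Measured so far:
compound 1, `O=c1c(-c2nn[nH]n2)c[nH]c2c(Cl)cccc12`: 0.078 mg/kg
compound 2, `O=c1c(-c2nn[nH]n2)c[nH]c2c(C(F)(F)F)cccc12`: 0.156 mg/kg

In a functional assay on the whole organism (strain Sprague-Dawley) for inhibition, with Rattus norvegicus as the target (a lower number here means that less compound is needed, a higher number that more compound is needed for the effect), compound 1 gives 0.078 mg/kg, and compound 2 gives 0.156 mg/kg. Among the compounds with values here, the only measured step, a 2.0-fold higher number from compound 1 to compound 2 (0.30 log units; within the scatter), places compound 1 within the scatter of compound 2, so the two numbers cannot be told apart.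

Compound 3, `O=c1c(-c2nn[nH]n2)c[nH]c2c(Cl)cc(Cl)cc12`, differs from compound 1 by chloro in place of hydrogen on an aromatic carbon. Within the data shown here, no measured step covers the entry of a second chloro onto the core; the one step on record, a 2.0-fold higher number from compound 1 to compound 2 (0.30 log units; within the scatter), exchanges one group for another on the same position and stayed within the scatter. The data therefore give no reason to expect a shift beyond the scatter in this assay for compound 3, in either direction.

Compound 3 is expected to give 0.08 mg/kg in this assay, with a range of 0.035 mg/kg to 0.2 mg/kg, which means an expected step of a 1.0-fold higher number from compound 1 to compound 3 (0.01 log units; within the scatter).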

Compound 3, minimum effective dose: > 0.156 mg/kg
Compound 3: only a limit was reported (the forecaster's own chance of this, stated with the estimate: 5%); middle value at least 1.9-fold (0.29 log units) from the limit.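

Chloro in place of hydrogen on this aromatic carbon, meta to a chloro group and para to a fused ring, is the first change on record at this position of the core of compound 1, and in this assay it gives an at least 2.0-fold higher number from compound 1 to compound 3 (0.30 log units; that floor lies within the scatter). Compound 3 is reported only as a limit, not as a number: the limit of > 0.156 mg/kg in this assay, at which 1 of the 3 values shown sits. The step therefore has a floor and no upper end, and since that floor lies within the scatter, the data do not yet separate compound 3 from compound 1, though they do leave room for a much larger step.

Going by these compounds, how far compound 3 actually lies from compound 1 remains open. Also open, on these data alone, is what a fluoro, a methoxy or an amine on this same carbon would give in this assay.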